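The source may report more compounds than this note shows. Statements on the series, on what has been measured and on what is new or still open speak of the compounds shown alone.

In a functional assay on A549 cells (Homo sapiens) for cytotoxicity, read by MTT assay, with a stated time of 48 h (on this read-out higher numbers stand for weaker inhibition and lower numbers for stronger inhibition), compound 1 `COc1cc(-n2c(-c3ccc(O)cc3)c[nH]c2=O)cc(OC)c1OC` gives > 50000 nM, which is a limit of the assay and not a number. Compound 2 `COc1ccc(-c2c[nH]c(=O)n2-c2cc(OC)c(OC)c(OC)c2)cc1` likewise gives only a limit, > 50000 nM. Compound 3 `COc1ccc(-c2c[nH]c(=O)n2-c2cc(OC)c(OC)c(OC)c2)cc1OC` also gives only a limit, > 50000 nM. All three compounds thus sit at the limit of > 50000 nM in this assay, at which 3 of the 3 values shown sit, and compound 3 has no number to build on. Compound 4 `COc1ccc(-c2c[nH]c(=O)n2-c2cc(OC)c(OC)c(OC)c2)cc1[N+](=O)[O-]` has nitro in place of methoxy on an aromatic carbon, ortho to a methoxy group: nitro in place of methoxy on an aromatic carbon. Within the data shown here, two measured steps bear on this change. One is a step that the two limits leave unreadable from compound 1 to compound 2, and the closer one is a step that the two limits leave unreadable from compound 2 to compound 3, which put in the methoxy that compound 4 gives up. Neither has a readable size, so they offer no measured guide to the size or direction of the new step, and the expectation is that this assay will stay at or close to the limit. The expected step is an at least 1.2-fold lower number from compound 3 to compound 4 (0.09 log units; that floor lies within the scatter). The estimate for compound 4 is 40000 nM, with an expected range from 10000 nM to 80000 nM.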

Compound 4, half-maximal inhibitory concentration: > 50000 nM
Compound 4 was reported as a limit (the forecaster's own chance of this, stated with the estimate: 65%); middle value at least 1.2-fold (0.09 log units) from the limit.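

Compound 4 gives > 50000 nM in this assay, which is a limit of the assay and not a number, so its steps from compound 3 and from compound 2 cannot be read. The compounds shown leave open which change to the shared core would give a readable number in this assay: the limit of > 50000 nM in this assay, at which 4 of the 4 values shown sit.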